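The compounds below may be only part of what the source reports. "The series", "measured", "known", "first", "only" and "open" are said of these compounds alone.

Measured so far:
compound 1 `Cc1c(Nc2nc(N)c3c(C#N)c(N4CCC[C@H]4C)n(C)c3n2)cnn1C` — 75 nM
compound 2 `Cc1c(Nc2nc(N)c3c(C#N)c(N4CCC[C@H]4C)n(C)c3n2)cnn1C1COC1` — 47 nM

In an assay on isolated protein for inhibition of Leucine-rich repeat serine/threonine-protein kinase 2 (Homo sapiens), read by TR-FRET and LanthaScreen, with stated times of 50 min and 30 min, in the presence of a further agent that is not named here (on this read-out higher numbers stand for weaker inhibition and lower numbers for stronger inhibition), compound 2 and compound 1 sit within the scatter of each other, as the step of a 1.6-fold lower number from compound 1 to compound 2 (0.20 log units; within the scatter) shows; compound 2 has no other neighbour. Compound 3 `Cc1c(Nc2nc(N)c3c(C#N)c(N4CCC[C@H]4C)n(C)c3n2)cnn1[C@@H]1CCOC1` differs from compound 2 by oxolan-3-yl in place of oxetan-3-yl on an aromatic nitrogen. For the measured compounds named here, the only measured step at this position, a 1.6-fold lower number from compound 1 to compound 2 (0.20 log units; within the scatter), stayed within the scatter, so for a 1.1-fold higher number from compound 2 to compound 3 (0.03 log units; within the scatter) no step beyond the scatter is expected in either direction. Compound 3 is therefore estimated at 50 nM, with a range from 20 nM to 125 nM.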

Compound 3, half-maximal inhibitory concentration: 20 nM
Beside the measured number, compound 3's estimate is 2.5-fold (0.40 log units) above it; measured number inside the range.
By their numbers in this assay, from the lowest: compound 3; then compounds 2 and 1 (each within the scatter of the next).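

In this assay this position on the aromatic nitrogen can move the number beyond the scatter, which the earlier pair did not show: oxolan-3-yl in place of oxetan-3-yl gives a 2.4-fold lower number from compound 2 to compound 3 (0.37 log units; beyond the scatter) and oxolan-3-yl in place of methyl gives a 3.8-fold lower number from compound 1 to compound 3 (0.57 log units; beyond the scatter). The five-membered ring thus separates from both smaller groups, though only modestly. Nothing at hand bears on why this step exceeds the scatter. Open, on these data alone, are the opposite configuration at the defined stereocentre of oxolan-3-yl and whether a six-membered oxan-4-yl group or a piperidin-4-yl amine continues the trend.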